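The compounds below may be only part of what the source reports. "The series", "measured", "known", "first", "only" and "open" are said of these compounds alone.

Compound 1 `CCOC(=O)c1ccc(-c2nn(Cc3ccc(Cl)cc3)c3ccccc23)cc1`, compound 2 `CCOC(=O)c1ccc(-c2nn(Cc3ccc(OC)cc3)c3ccccc23)cc1` and compound 3 `CCOC(=O)c1cccc(-c2nn(Cc3ccccc3)c3ccccc23)c1` share one core and were tested in a functional assay on cells (Platelet, Homo sapiens) for inhibition; on this read-out lower numbers stand for stronger inhibition and higher numbers for weaker inhibition. For compound 1 the value is a limit of the assay, > 10000 nM. For compound 2 the value is likewise a limit, > 10000 nM. For compound 3 the value is also a limit, > 10000 nM. Going by the values given here, the only measured step, a step that the two limits leave unreadable from compound 1 to compound 2, is a methoxy in place of chloro on an aromatic carbon, and its size cannot be read because both ends are limits. Compound 4 `CCCCn1nc(-c2ccc(C(=O)OCC)cc2)c2ccccc21` is the compound still to be measured; its change from compound 2 is propyl in place of 4-methoxyphenyl on a saturated chain carbon bound to an aromatic nitrogen. Among the compounds with values here, this step has no measured counterpart, and nothing about its size can be taken from the other compounds, since (the limit of > 10000 nM in this assay, at which 3 of the 3 values shown sit). No direction or size beyond the scatter is therefore expected in this assay, and another limit is the most likely outcome. The value of compound 4 is estimated at 20000 nM, within 5000 nM to 100000 nM. The expected step is a step that the limit leaves unreadable from compound 2 to compound 4.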

Compound 4, half-maximal inhibitory concentration: > 10000 nM
Compound 4: only a limit was reported (the forecaster's own chance of this, stated with the estimate: 80%); the middle value does not contradict the limit.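

Compound 4 ends at a limit of the assay, as do compound 1 and compound 2, so the steps from either of them to compound 4 cannot be read: the limit of > 10000 nM in this assay, at which 4 of the 4 values shown sit. The compounds shown leave open which change to this shared core, if any, would give a readable value in this assay.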